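A bromophenyl sulfonyl variant awaits its cell readout

The source may hold more compounds than are shown below. What is called first, only, known or untested is meant among the compounds shown, and "the series" means these compounds.

Compound 2 `COc1ccc(-c2cc(=O)c3c(OC)cc(OC)cc3n2S(=O)(=O)c2cc(Cl)cc(Cl)c2O)cc1` carries a 3,5-dichloro-2-hydroxyphenyl on its sulfonyl sulfur. In an ADME assay on BJ cells (Homo sapiens) for antiproliferative activity, with a stated time of 72 h (a higher number here means that more compound is needed for the effect, a lower number that less compound is needed), compound 2 gives only a limit, > 37900 nM. Compound 1 `COc1ccc(-c2cc(=O)c3c(OC)cc(OC)cc3n2S(=O)(=O)c2ccc(C=O)cc2)cc1` differs from it in the aryl on that sulfur. In this assay compound 1 also gives only a limit, > 34400 nM. The step that the two limits leave unreadable from compound 1 to compound 2 therefore has no readable size because the limit of > 34400 nM in this assay, at which 1 of the 2 values shown sits, and the limit of > 37900 nM in this assay, at which 1 of the 2 values shown sits, both mark limits.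

Compound 3 `COc1ccc(-c2cc(=O)c3c(OC)cc(OC)cc3n2S(=O)(=O)c2cccc(Br)c2)cc1` introduces (3-bromophenyl in place of 3,5-dichloro-2-hydroxyphenyl on a sulfonyl sulfur). Going by the values given here, no measured step bears readably on this change, since the only one recorded, from compound 1 to compound 2, runs between two limits. Compound 3 is therefore expected to sit at or near the same limit, with an estimate of 38000 nM and a range from 15000 nM to 100000 nM. The step that the limit leaves unreadable from compound 2 to compound 3 is expected not to exceed the scatter.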

Compound 3, half-maximal effective concentration: > 58600 nM
Compound 3 ended at the assay's limit (the forecaster's own chance of this, stated with the estimate: 75%); middle value at least 1.5-fold (0.18 log units) from the limit.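

In this assay, compound 3 gives only a limit, as do compound 1 and compound 2, so no step among these three compounds can be read. The compounds shown leave open how these three aryl groups on the sulfonyl sulfur would rank.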